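One Side Group Exchanged on a Shared Core

This account rests on a few compounds, and the source may have more. Where it says the series, first, only, none or still open, it means among the compounds named here.

Of the compounds shown here, two sharing a core have been measured so far. In an ADME assay for permeability, using PAMPA, with a stated time of 4 h, at pH 7.4 (on this read-out lower numbers stand for lower permeability and higher numbers for higher permeability), compound 1 (`CN(C[C@@H]1Cc2ncccc2CN1)[C@H]1CCCc2cccnc21`) gives 1000 nm/s as its reading, while compound 2 (`NC(=O)NC/C=C\CN(C[C@H]1Cc2ncccc2CN1)[C@H]1CCCc2cccnc21`) gives 2 nm/s as its reading. Compound 2 therefore holds the lower of the two numbers, and its gap to compound 1 lies well beyond the scatter of repeated measurements.

Compound 3 (`c1cnc2c(c1)CN[C@@H](CN(CCCCNC1COC1)[C@H]1CCCc3cccnc31)C2`) has not yet been measured. Among the compounds with values here, it differs from compound 2 by a group of 8 heavy atoms (6 carbon, 1 nitrogen, 1 oxygen; one four-membered non-aromatic ring with 1 hetero atom) in place of a group of 7 heavy atoms (4 carbon, 2 nitrogen, 1 oxygen; no ring), on a saturated chain carbon bound to an amine nitrogen as the one structural change. The group that leaves has 2 double bonds outside aromatic rings, and the group that enters has one four-membered non-aromatic ring with 1 hetero atom.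

Within the data shown here, no measured step of this kind is available, so the expectation rests on the two readings alone. Compound 1 reads 1000 nm/s and compound 2 reads 2 nm/s on the same scale, which shows that a compound with this core can give a far greater number than compound 2 does. The expected change in this assay is a 25-fold higher number from compound 2 to compound 3 (1.40 log units; beyond the scatter) as an upward step beyond the scatter. For compound 3 the estimated value is 50 nm/s with an expected range from 10 nm/s to 250 nm/s as the likely span.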

Compound 3, apparent permeability: 300 nm/s
The estimate for compound 3 lay 6.0-fold (0.78 log units) below the measured number, and the stated range ends below it.
By their numbers in this assay, from the lowest: compound 2; then compound 3; then compound 1.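

The exchange on a saturated chain carbon bound to an amine nitrogen gives a 150-fold higher number from compound 2 to compound 3 (2.18 log units; beyond the scatter) in this assay, which shows that this one place can move the read-out by a large margin. It also shows that the low number of compound 2 does not hold for every long side group at this place: a group of 8 heavy atoms with one four-membered non-aromatic ring with 1 hetero atom stands where a group of 7 heavy atoms with no ring stood, and the number still rises. Nothing measured alongside these compounds bears on what lies behind this step.

The ring, the loss of the 2 double bonds outside aromatic rings and the change in hydrogen-bond donors and acceptors all come together in this single exchange, so the compounds shown cannot tell them apart. From the compounds shown here alone, how a carboxylic acid or a primary amine at the end of the chain, or a longer chain, would read in this assay remains open.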